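The compounds below may be only part of what the source reports. "The series", "measured", "known", "first", "only" and "open" are said of these compounds alone.

Compound 1, `C/C=C/C=C/C(=O)N(Cc1ccc(OC)c(O)c1)c1cc(OC)c(OC)c(OC)c1`, is the reference point of this small set. In a functional assay on KYSE-450 cells (Homo sapiens) for inhibition, read by MTT assay, with a stated time of 48 h (a lower number here means a stronger inhibitor, a higher number a weaker inhibitor), compound 1 gives 180 nM, the lowest of the three numbers measured. The two secondary amines are far behind: compound 2, `COC(=O)c1cc(CNc2cc(OC)c(OC)c(OC)c2)ccc1OC`, gives 41100 nM in this assay, and compound 3, `COc1cc(NCc2cccc(O)c2)cc(OC)c1OC`, gives 71300 nM, so both gaps to compound 1 lie well beyond the scatter, and compound 1 is clearly the strongest of the three. No pair of these compounds differs in only one place, so nothing here says how much a single change on this scaffold is worth.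

Compound 4, `C/C=C/C(=O)N(Cc1ccc(OC)c(O)c1)c1cc(OC)c(OC)c(OC)c1`, keeps the whole tertiary-amide core of compound 1 and shortens only the acyl chain: methyl in place of prop-1-en-1-yl on a double-bonded chain carbon bound to a double-bonded chain carbon. The change removes one double bond from the chain and nothing else. Because compound 1 gives 180 nM and the altered part is small and remote from the rest, the step from compound 1 to compound 4 is expected to be small and within the scatter, if anything toward a higher number: a 1.9-fold higher number from compound 1 to compound 4 (0.29 log units; within the scatter). Compound 4 is therefore estimated at 350 nM in this assay, with a range from 120 nM to 1200 nM.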

Compound 4, half-maximal inhibitory concentration: 67 nM
Estimate against measurement, compound 4: 5.2-fold (0.72 log units) above; measured number outside the range, below it.
By their numbers in this assay, from the lowest: compound 4; then compound 1; then compounds 2 and 3 (each within the scatter of the next).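

With methyl in place of prop-1-en-1-yl on a double-bonded chain carbon bound to a double-bonded chain carbon, the only single-place step shown gives a 2.7-fold lower number from compound 1 to compound 4 (0.43 log units; beyond the scatter) in this assay. This position therefore tolerates the shorter chain: in this pair, the penta-1,3-dien-1-yl group is not needed, and replacing it with prop-1-en-1-yl, with one double bond fewer, brings a modest gain rather than a loss. Nothing available explains why the number moves in this direction.

Within the data shown here, the single pair cannot separate the effect of the lost double bond from that of the lost chain length. It also leaves open how the number would respond to hydrogen, an ethyl group, an amine or a carboxylic acid at the same chain carbon, or to a fully saturated acyl chain.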